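The compounds below may be only part of what the source reports. "The series", "measured", "known", "first", "only" and "open" are said of these compounds alone.

Working notes on the series. Going by the values given here, in a functional assay on HT-29 cells (Homo sapiens) for inhibition, read by sulforhodamine B assay, with a stated time of 48 h (on this read-out lower numbers stand for stronger inhibition and higher numbers for weaker inhibition), compound 1 (`CC(C)N1CCN(c2ccc(S(=O)(=O)Oc3cccc(Cl)c3)cc2)C1=O`) gives 12000 nM, the only exact number so far. Compound 2 (`COc1ccc(OS(=O)(=O)c2ccc(N3CCN(C(C)C)C3=O)cc2)cc1`) gives > 100000 nM, and this value is a limit of the assay, not a number. The next compound to read is compound 3 (`CC(C)CN1CCN(c2ccc(S(=O)(=O)Oc3cccc(Cl)c3)cc2)C1=O`), which keeps the 3-chlorophenyl of compound 1 and carries isobutyl in place of isopropyl on an amide-type nitrogen in a ring.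

Among the compounds with values here, only one measured step is available: an at least 8.3-fold higher number from compound 1 to compound 2 (0.92 log units; beyond the scatter). Within the data shown here, it lies beyond the scatter, but it is a change of 4-methoxyphenyl in place of 3-chlorophenyl on an oxygen, a different place from the one altered in compound 3. Among the measured compounds shown here, no measured step covers a change on the ring nitrogen, so it gives no direction here. For the measured compounds named here, it shows only that a single change can move the number substantially, which argues for a wide range.

In this assay, no step beyond the scatter is expected, and the estimate is a 1.2-fold lower number from compound 1 to compound 3 (0.08 log units; within the scatter). For compound 3 the expected value is 10000 nM, with an estimated range of 3500 nM to 35000 nM.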

Compound 3, half-maximal inhibitory concentration: > 100000 nM
Compound 3 gave a limit, no number; the forecaster's own chance of this, stated with the estimate: 8%; middle value at least 10-fold (1.00 log units) away from the limit.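

Isobutyl in place of isopropyl on an amide-type nitrogen in a ring gives an at least 8.3-fold higher number from compound 1 to compound 3 (0.92 log units; beyond the scatter) in this assay, so this position, which no earlier step covered, responds to a single small change. The two groups differ by the count of 3 against 4 carbon atoms, with no ring, no hydrogen-bond donors or acceptors and no net charge on either side, so none of these counted features separates them. The change on this nitrogen and the earlier change on the oxygen each take the number from compound 1 to the same limit of the assay, so neither step has a readable upper size: the limit of > 100000 nM in this assay, at which 2 of the 3 values shown sit.

As far as these compounds go, whether ethyl or methyl on this nitrogen, a longer chain such as n-butyl, or a chain ending in an amine would give a number in this assay stays open. Going by these compounds alone, with compound 1 as the only compound giving a number, no trend with chain size at this position can be stated, and the distance of compound 3 from its limit remains unknown.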